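The source may hold more compounds than are shown below. What is called first, only, known or untested is meant among the compounds shown, and "the series" means these compounds.

Series values in an ADME assay on the whole organism (strain CD-1) for metabolic stability, with Mus musculus as the target, at a dose of 3 mg/kg by the intravenous route; a higher number here means that the compound lasts longer, a lower number that the compound disappears faster:

- Compound 1 `CN(Cc1ccccc1OCCCCCC(=O)O)C(=O)c1ccc(-c2ccco2)cc1`: 1.7 h
- Compound 2 `C[C@H](CCCOc1ccccc1CN(C)C(=O)c1ccc(-c2ccco2)cc1)CC(=O)O`: 3.9 h
- Compound 3 `C[C@@H](CCCOc1ccccc1CN(C)C(=O)c1ccc(-c2ccco2)cc1)CC(=O)O`: 2 h

Compound 3 sits within the scatter of both neighbours, as shown by a 1.2-fold higher number from compound 1 to compound 3 (0.07 log units; within the scatter) and a 2.0-fold lower number from compound 2 to compound 3 (0.29 log units; within the scatter). Only a 2.3-fold higher number from compound 1 to compound 2 (0.36 log units; beyond the scatter) lies beyond the scatter, and it is modest.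

The next structure is compound 4 `CN(Cc1ccccc1OCCC/C=C/C(=O)O)C(=O)c1ccc(-c2ccco2)cc1`. The change is 2-carboxyethenyl in place of 1-(carboxymethyl)ethyl on a saturated chain carbon, three bonds along the chain from an oxygen on an aromatic ring. Cut one bond further out, it reads 4-(carboxymethyl)pentyl to 5-carboxypent-4-en-1-yl.

Among the measured compounds shown here, no measured step covers a 2-carboxyethenyl group, so the evidence is indirect. The three steps above are all changes on this same chain, and they span a modest range at most. Starting from compound 3 at 2 h, no shift beyond the scatter is expected in this assay.

The expected change is a 1.1-fold lower number from compound 3 to compound 4 (0.05 log units; within the scatter).

For compound 4 the estimated half-life is 1.8 h, with an expected range of 0.9 h to 3.6 h.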

Compound 4, half-life: 1.9 h
Compound 4: the middle estimate sits 1.1-fold (0.02 log units) below what was measured; the range from low to high includes it.
By their numbers in this assay, from the lowest: compounds 1, 4, 3 and 2 (each within the scatter of the next, the first and the last beyond it).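

In this assay, the 2-carboxyethenyl group gives a chain end that cannot be told apart from the saturated chains of compounds 1 and 3, as a 1.1-fold higher number from compound 1 to compound 4 (0.05 log units; within the scatter) and a 1.1-fold lower number from compound 3 to compound 4 (0.02 log units; within the scatter) show. Compound 2 stands apart from compound 4, with a 2.1-fold lower number from compound 2 to compound 4 (0.31 log units; beyond the scatter), and from compound 1, with a 2.3-fold higher number from compound 1 to compound 2 (0.36 log units; beyond the scatter), though both steps are modest. A role for configuration remains unproven, with a 2.0-fold lower number from compound 2 to compound 3 (0.29 log units; within the scatter), although this pair isolates that one feature: the fact that compounds 2 and 3 differ only in the configuration as drawn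

Still open, going by these compounds, is how the half-life responds when a tetrazole or a primary amide replaces the carboxylic acid at the chain end. Also open, on these data alone, is whether a chain carrying both a methyl group and a double bond follows compound 2 or compound 4.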